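Methyl on the Fused Core of Two Aryl Hydroxy Compounds

A few compounds are considered here, and "the series" means these few. Any claim that something is new, unique, unknown or untested is made for them only; others in the source may bear on it.

The study concerns three measured compounds and one that has not yet been measured. Compound 1 `COc1ccc(-c2cc(O)c3cccnc3n2)cc1` gives 53700 nM in a functional assay on U-251 cells (Homo sapiens); a higher number here means a weaker inhibitor of growth, a lower number a stronger inhibitor of growth. Compound 2 `COc1ccc(-c2cc(O)c3cc(C)cnc3n2)cc1` carries a methyl group on the fused core and, in this assay, compound 2 gives 4170 nM. The change between them is methyl in place of hydrogen on an aromatic carbon, and the step it made is a 13-fold lower number from compound 1 to compound 2 (1.11 log units; beyond the scatter).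

Compound 3 `COc1ccccc1-c1cc(O)c2cccnc2n1` bears its methoxy group on the pendant phenyl ring in a different arrangement from compound 1; the difference between the two cores is not broken down here. In this assay compound 3 gives 67600 nM, which lies within the scatter of compound 1.

Compound 4 `COc1ccccc1-c1cc(O)c2c(C)ccnc2n1` is derived from compound 3 by methyl in place of hydrogen on an aromatic carbon. This is the same kind of change as that from compound 1 to compound 2, but not the same: in compound 2 the methyl sits two atoms from the ring nitrogen, meta to a fused ring and para to a fused ring, whereas in compound 4 it sits ortho to a fused ring, meta to a fused ring and opposite the ring nitrogen.

Because a 13-fold lower number from compound 1 to compound 2 (1.11 log units; beyond the scatter) was a large step, the expectation for compound 4 is a lower number than compound 3, but the shifted position of the methyl gives reason for a more cautious estimate; the expected step is a 4.5-fold lower number from compound 3 to compound 4 (0.65 log units; beyond the scatter). Compound 4 is therefore estimated at 15000 nM, with a range from 4000 nM to 60000 nM.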

Compound 4, concentration for 50% growth inhibition: 35500 nM
Compound 4: the middle estimate sits 2.4-fold (0.37 log units) below what was measured; the range from low to high includes it.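

Placed on the core of compound 3 in this assay, methyl in place of hydrogen on an aromatic carbon gives a 1.9-fold lower number from compound 3 to compound 4 (0.28 log units; within the scatter), so on this core the change cannot be told apart from the scatter of repeated measurements. The change therefore did not carry over from one core to the other at the size it had before: the same change on two cores in this assay, a 13-fold lower number (1.11 log units; beyond the scatter) from compound 1 to compound 2 and a 1.9-fold lower number (0.28 log units; within the scatter) from compound 3 to compound 4, 6.8-fold (0.83 log units) apart, beyond the scatter of two such steps

This does not show that the core alone sets the size of the step, since the two pairs differ both in the arrangement of the methoxy group on the pendant phenyl ring and in where the methyl sits, and two pairs cannot separate these differences or show which of them matters.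

The compounds shown leave open what the methyl would do at the place it holds in compound 2 if it stood on the core of compound 3, and what it would do at the place it holds in compound 4 if it stood on the core of compound 1. They also leave open whether a longer chain such as ethyl, or an amine, at either place would follow the methyl steps.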